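This account rests on a few compounds, and the source may have more. Where it says the series, first, only, none or still open, it means among the compounds named here.

In an assay on Sf9 cells for inhibition of inhibitor of nuclear factor kappa-B kinase subunit epsilon (Homo sapiens), read by ADP-Glo, with a stated time of 60 min (a lower number here means a stronger inhibitor, a higher number a weaker inhibitor), three compounds have been measured so far. Compound 1, `Cc1[nH]nc(N)c1-c1ccc(OCc2ccccc2)cc1`, gives 15400 nM, a weak but countable result. Compound 2, `CCC(=O)n1nc(C)c(-c2ccc(Cl)c(Cl)c2)c1N`, reaches only the limit of the assay and gives > 100000 nM, so no number is known for it. Compound 3, `CC(=O)n1nc(C)c(-c2ccc(Cl)cc2)c1N`, likewise gives only the limit, > 100000 nM. Compound 2 therefore stands at the limit of > 100000 nM in this assay, at which 2 of the 3 values shown sit, which is the weakest position the measurement can report, and nothing separates it from compound 3 on the numbers shown. For the measured compounds named here, no step between two measured compounds that differ in a single place exists here, so no size of change has yet been observed in this assay.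

The next compound to be measured is compound 4, `CCNC(=O)n1nc(C)c(-c2ccc(Cl)c(Cl)c2)c1N`. It differs from compound 2 in one place: ethylamino in place of ethyl on a carbonyl carbon.

With compound 2 sitting at the limit, the step cannot be seen as a number at all unless compound 4 turns out clearly stronger. Going by the values given here, no measured step in this assay supports such a jump, so the expected step from compound 2 to compound 4 in this assay is a number no higher from compound 2 to compound 4 (the limit leaves the size open), which amounts to none beyond the scatter. Compound 4 is therefore estimated at 100000 nM, within a range from 30000 nM to 300000 nM, and most likely the assay will again report only its limit.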

Compound 4, half-maximal inhibitory concentration: > 100000 nM
Compound 4 was reported as a limit; the forecaster's own chance of this, stated with the estimate: 70%; the middle value sits exactly at the limit.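

Compound 2 and compound 4 are both reported only as limits of this assay, so no size can be read for the change from ethyl to ethylamino on a carbonyl carbon. The compounds shown leave open whether this change alters inhibition at all, and how strong either compound truly is.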